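This account rests on a few compounds, and the source may have more. Where it says the series, first, only, none or still open, it means among the compounds named here.

Measured in a functional assay on NCI-H1993 cells (Homo sapiens) for inhibition, read by CCK-8 assay, with a stated time of 72 h; on this read-out lower numbers stand for stronger inhibition and higher numbers for weaker inhibition:
- compound 1 `CCC(c1ccc2ncccc2c1F)n1cnc2ncc(-c3cnc4ccccc4c3)nc21`: "not determined" (no result reported)
- compound 2 `COC(=O)c1ccc(/C=N/CNC(C)c2ccc3ncccc3c2)cc1F`: 1110 nM

Among the compounds with values here, compound 2 carries the only number so far, since compound 1 has no result. Its standing therefore cannot be ranked against any other compound. The next compound to be tested in this assay is compound 3 `CC(NC/N=C/c1ccc(C(N)=O)c(F)c1)c1ccc2ncccc2c1`. It keeps the framework of compound 2 and changes one group, methoxycarbonyl to carbamoyl: amino in place of methoxy on a carbonyl carbon. Within the data shown here, no measured step gauges this swap, so the size of the change is a judgement anchored only on compound 2 at 1110 nM. A modest shift towards stronger inhibition is expected, with the estimated 1.9-fold lower number from compound 2 to compound 3 (0.27 log units; within the scatter) not far beyond the usual scatter. Compound 3 is expected at 600 nM, with an estimated range of 120 nM to 2500 nM.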

Compound 3, half-maximal inhibitory concentration: 238 nM
Beside the measured number, compound 3's estimate is 2.5-fold (0.40 log units) above it; the measured number falls inside the stated range.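

In this assay, within the data shown here, amino in place of methoxy on a carbonyl carbon gives a 4.7-fold lower number from compound 2 to compound 3 (0.67 log units; beyond the scatter), the first measured step. This place on the framework therefore responds to the change from methoxycarbonyl to carbamoyl, and the methoxycarbonyl group is not needed for inhibition in these cells, since the carbamoyl compound gives the lower number. No measured data on hand account for the size of this step.

This single pair cannot separate the entry of amino, with its hydrogen-bond donor, from the departure of methoxy. Methylamino or dimethylamino on the same carbonyl carbon would bear on that question, and a carboxylic acid at this place remains an open comparison, as does any change elsewhere on the framework.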